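The source may hold more compounds than are shown below. What is called first, only, known or untested is meant among the compounds shown, and "the series" means these compounds.

Of the compounds shown here, three built on a shared core have been measured in a functional assay on HT-29 cells (Homo sapiens) for antiproliferative activity, read by CellTiter-Glo, with a stated time of 72 h; on this read-out higher numbers stand for weaker inhibition and lower numbers for stronger inhibition. Compound 1 `CCc1cc(Br)ccc1S(=O)(=O)N1CCC(N2CCC(C)CC2)CC1` gives 0.5 nM, compound 3 `CC1CCN(C2CCN(S(=O)(=O)c3ccccc3-c3ccccc3)CC2)CC1` gives 0.74 nM, and compound 2 `CC1CCN(C2CCN(S(=O)(=O)c3ccccc3Br)CC2)CC1` gives 3 nM. Compound 2 therefore has the highest number of the three, and the gaps to both others lie beyond the scatter, making it the weakest inhibitor of this small set.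

Compound 4 `CC1CCN(C2CCN(S(=O)(=O)c3cccc(Br)c3)CC2)CC1` has not yet been measured. It differs from compound 2 by a single change, 3-bromophenyl in place of 2-bromophenyl on a sulfonyl sulfur.

For the measured compounds named here, only one measured step bears on this change: a 4.1-fold lower number from compound 2 to compound 3 (0.61 log units; beyond the scatter), with phenyl in place of bromo on an aromatic carbon. That step is modest, though beyond the scatter. It swaps one group for another, whereas compound 4 keeps the same atoms joined differently, so it is only a rough guide. Going by the values given here, no measured pair shows directly what this kind of change does. Compound 1 differs from compound 2 in more than one place and gives no clean comparison.

A modest shift is therefore expected, with the direction uncertain and a slight lean towards weaker inhibition. The estimated change is a 1.7-fold higher number from compound 2 to compound 4 (0.22 log units; within the scatter). The estimate for compound 4 is 5 nM, with an expected range from 1.5 nM to 20 nM.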

Compound 4, half-maximal inhibitory concentration: 1.2 nM
Compound 4: middle estimate off by 4.2-fold (0.62 log units), on the high side; measured number below the stated range.
By their numbers in this assay, from the lowest: compounds 1, 3 and 4 (each within the scatter of the next, the first and the last beyond it); then compound 2.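

Moving the bromine, with 3-bromophenyl in place of 2-bromophenyl on the sulfonyl sulfur, gives a 2.5-fold lower number from compound 2 to compound 4 (0.40 log units; beyond the scatter) in this assay, so this arrangement alone changes the read-out beyond the scatter, even though no atom is gained or lost. The earlier step, a 4.1-fold lower number from compound 2 to compound 3 (0.61 log units; beyond the scatter), swapped bromo for phenyl and so changed the group itself, whereas this pair shows that the placement of the same bromine also counts, with the 2-bromophenyl of compound 2 giving the weaker inhibition of the two. No measurement shown here explains why the two arrangements differ.

This single pair shows the effect of moving bromine only, on this one shared core, so it cannot show whether the same move would lower the number for any other group on the ring. It also leaves open whether an amine or a carboxylic acid in place of the bromine on the 3-bromophenyl group of compound 4 would keep the number near that of compound 4 or shift it in either direction.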